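The compounds below may be only part of what the source reports. "The series", "measured", "known", "first", "only" and "open" are said of these compounds alone.

Going by the values given here, in an ADME assay on L6 cells (Rattus norvegicus) for cytotoxicity, read by resazurin assay, with a stated time of 72 h (a lower number here means a stronger inhibitor, a higher number a weaker inhibitor), compound 1 `N=C(N)c1ccc(OCc2cccc(C(=N)N)c2)cc1` gives 5930000 nM and compound 2 `N=C(N)c1cccc(COc2ccc(C(=N)N)cc2Cl)c1` gives 13900000 nM as the highest of the two numbers so far. Compound 3 `N=C(N)c1cccc(COc2c(Cl)cc(C(=N)N)cc2Cl)c1` differs from compound 2 by one further replacement: chloro in place of hydrogen on an aromatic carbon with chloro in place of hydrogen on an aromatic carbon. Among the compounds with values here, the one measured step of the same kind is a 2.3-fold higher number from compound 1 to compound 2 (0.37 log units; beyond the scatter) and it bears directly on this change, though it stands alone. A similarly modest rise is therefore expected, and a 1.4-fold higher number from compound 2 to compound 3 (0.16 log units; within the scatter) is the estimated step here. For compound 3 the estimated value is 20000000 nM with an expected range from 8000000 nM to 45000000 nM at its upper end.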

Compound 3, half-maximal inhibitory concentration: 570000 nM
Beside the measured number, compound 3's estimate is 35-fold (1.55 log units) above it, and the stated range ends above it.
By their numbers in this assay, from the lowest: compound 3; then compound 1; then compound 2.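

In this assay, the second chloro, ortho to a large group and meta to the first chloro, reverses the direction of the earlier replacement: a 2.3-fold higher number from compound 1 to compound 2 (0.37 log units; beyond the scatter) is followed by a 24-fold lower number from compound 2 to compound 3 (1.39 log units; beyond the scatter). The same replacement therefore has no fixed outcome across these two positions on this ring, and here the step is large. Nothing measured here accounts for the reversal. The compounds shown leave open whether a methyl, a methoxy or an amine in place of this chloro would give a similar fall, and whether this chloro would do so without the other one.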